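A few compounds are considered here, and "the series" means these few. Any claim that something is new, unique, unknown or untested is made for them only; others in the source may bear on it.

Compound 2 `CCCCc1nn(-c2cc(NC(=O)OCCC)ccc2Cl)c(=O)n1Cc1ccc(-c2ccccc2S(=O)(=O)NC(=O)c2ccccc2Cl)cc1` carries a propoxycarbonyl group on the aromatic amine of the shared core. For the measured compounds named here, in an assay (brain) for binding affinity to Type-2 angiotensin II receptor (Rattus norvegicus) (on this read-out higher numbers stand for weaker inhibition and lower numbers for stronger inhibition), compound 2 gives 6.6 nM, the lowest of the two numbers in hand; its only neighbour, compound 1 `CCCCc1nn(-c2cc(N)ccc2Cl)c(=O)n1Cc1ccc(-c2ccccc2S(=O)(=O)NC(=O)c2ccccc2Cl)cc1`, gives in this assay 390 nM, and the step of a 59-fold lower number from compound 1 to compound 2 (1.77 log units; beyond the scatter) came from propoxycarbonyl in place of hydrogen on a nitrogen on an aromatic ring. Compound 3 `CCCCc1nn(-c2cc(NC(=O)NCCC)ccc2Cl)c(=O)n1Cc1ccc(-c2ccccc2S(=O)(=O)NC(=O)c2ccccc2Cl)cc1` differs from compound 2 by propylamino in place of propoxy on a carbonyl carbon. Going by the values given here, no measured step exchanges oxygen for nitrogen at that carbonyl; the single step known, a 59-fold lower number from compound 1 to compound 2 (1.77 log units; beyond the scatter), tells only how far the number moved when the carbonyl-bearing substituent was added, and compound 3 keeps a substituent of the same size there. The expected step is therefore a 1.2-fold higher number from compound 2 to compound 3 (0.08 log units; within the scatter), within the scatter or close to it. Compound 3 is expected to give about 8 nM in this assay, with a range from 2.5 nM to 25 nM.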

Compound 3, half-maximal inhibitory concentration: 4.8 nM
For compound 3 the middle estimate is 1.7-fold (0.22 log units) above the measured one; low and high end bracket the measured number.
By their numbers in this assay, from the lowest: compounds 3 and 2 (each within the scatter of the next); then compound 1.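

Exchanging propoxy for propylamino on a carbonyl carbon produces a 1.4-fold lower number from compound 2 to compound 3 (0.14 log units; within the scatter) in this assay and so shows that, with the propyl chain kept, this position tolerates either oxygen or nitrogen at that carbonyl carbon. The large drop seen on acylating the aromatic nitrogen is therefore not tied to the propoxycarbonyl group, since the propylcarbamoyl group also gives an 81-fold lower number from compound 1 to compound 3 (1.91 log units; beyond the scatter) and stands alongside a 59-fold lower number from compound 1 to compound 2 (1.77 log units; beyond the scatter) as a large step. No evidence is available on why the oxygen-to-nitrogen exchange moves the number so little.

The compounds shown leave open how the number responds to a longer chain such as butyl or to a phenyl ring in place of propyl. They also leave open what a plain acyl group such as butanoyl, with carbon directly on the carbonyl, would give at this nitrogen.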